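The compounds below may be only part of what the source reports. "The series", "measured", "known", "first", "only" and "open" are said of these compounds alone.

Measured so far:
- Compound 1, `O=C(/N=C1\NC2(CCCCO2)CCS1)c1ccccc1`: 5 mg/kg
- Compound 2, `Cc1ccc(C(=O)/N=C2\NC3(CCCCO3)CCS2)cc1`: 60 mg/kg

In a functional assay on the whole organism (strain CF-1) with Mus musculus as the target, in the writhing test, with a stated time of 15 min (a higher number here means that more compound is needed for the effect, a lower number that less compound is needed), compound 1 gives 5 mg/kg and compound 2 gives 60 mg/kg. The single step between them, a 12-fold higher number from compound 1 to compound 2 (1.08 log units; beyond the scatter), leaves compound 2 with the higher of the two numbers shown, and the only measured neighbour is compound 1.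

Compound 3, `CC(C)(C)C(=O)/N=C1\NC2(CCCCO2)CCS1`, has not yet been measured in this assay. Its change from compound 2 is tert-butyl in place of 4-methylphenyl on a carbonyl carbon. Among the compounds with values here, no measured step follows exactly this change. Within the data shown here, the one step at hand, a 12-fold higher number from compound 1 to compound 2 (1.08 log units; beyond the scatter), shows that adding a methyl to the aromatic ring raised the number by a large margin; compound 3 drops that whole 4-methylphenyl and brings in a tert-butyl with no ring, so the effect of the methyl is removed, but the effect of losing the aromatic ring is unknown. Given that, compound 3 is expected to come in lower than compound 2, by a step of a 4.0-fold lower number from compound 2 to compound 3 (0.60 log units; beyond the scatter), with wide uncertainty. The estimate for compound 3 in this assay is 15 mg/kg, within a range of 3 mg/kg to 80 mg/kg.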

Compound 3, dose for half-maximal effect: 200 mg/kg
Compound 3: middle estimate off by 13-fold (1.12 log units), on the low side; the whole stated range lies below it.
By their numbers in this assay, from the lowest: compound 1; then compound 2; then compound 3.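

The result shows that, on this carbonyl carbon, taking away the methyl-bearing ring does not bring back the low number of compound 1. In this assay, tert-butyl in place of 4-methylphenyl gives a 3.3-fold higher number from compound 2 to compound 3 (0.52 log units; beyond the scatter), a modest move, while tert-butyl in place of phenyl gives a 40-fold higher number from compound 1 to compound 3 (1.60 log units; beyond the scatter), a large one. Among these three compounds, both replacements of the plain phenyl, the one adding a methyl to the ring and the one swapping the ring for tert-butyl, raise the number, and none of the compounds goes against this; nothing at hand gives a reason for these shifts at this position.

With a single ring-free group and a single ring substituent, the compounds leave open whether a cyclohexyl group or a straight butyl chain on the carbonyl carbon would track tert-butyl or phenyl. They also leave open whether a fluorine or a methoxy group on the phenyl ring would raise the number as the methyl does, or whether that rise is particular to the methyl.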